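Phenyl to 4-chlorophenyl: compound 2 to compound 3

The source may hold more compounds than are shown below. What is called first, only, known or untested is meant among the compounds shown, and "the series" means these compounds.

Of the compounds shown here, two have been tested in a functional assay on MCF7 cells (Homo sapiens) for inhibition, read by sulforhodamine B assay, with a stated time of 48 h; a lower number here means a stronger inhibitor of growth, a higher number a weaker inhibitor of growth. Compound 1 `CCOC(=O)c1nn(-c2ccc(Cl)cc2)c(-c2ccc(F)cc2)c1CNC(C)(C)C` gives only limits (> 582000 nM; > 537000 nM (2 entries)) and no number. Compound 2 `CC(C)(C)NCc1c(C(=O)O)nn(-c2ccccc2)c1-c1ccc(F)cc1` also stands only as a limit (> 680000 nM), with no single number. Compound 3 `CC(C)(C)NCc1c(C(=O)O)nn(-c2ccc(Cl)cc2)c1-c1ccc(F)cc1` differs from compound 2 by chloro in place of hydrogen on an aromatic carbon with chloro in place of hydrogen on an aromatic carbon, para to a large group, so that phenyl becomes 4-chlorophenyl. Within the data shown here, no measured step between compounds is available to size this change. The expected at least 1.0-fold lower number from compound 2 to compound 3 (0.02 log units; that floor lies within the scatter) is therefore estimated to stay within the scatter, with no direction assigned. That expectation rests on the limit of compound 2 (> 680000 nM). For compound 3 the estimated value is 640000 nM with an expected range (300000 nM to 900000 nM).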

Compound 3, concentration for 50% growth inhibition: 270000 nM
For compound 3 the middle estimate is 2.4-fold (0.37 log units) above the measured one, and the stated range ends above it.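

The position para to a large group on this aromatic ring responds to substitution: chloro in place of hydrogen gives an at least 2.5-fold lower number from compound 2 to compound 3 (0.40 log units; beyond the scatter) in this assay, and compound 3 is the only compound shown with a single number. That step is a floor and not a full size, because compound 2 stands only as a limit: the limit of > 680000 nM in this assay, at which 1 of the 3 values shown sits. Compound 1 also carries 4-chlorophenyl, but as an ethyl ester where compound 3 has the carboxylic acid, and it stands only as limits: the several entries of compound 1 in this assay, > 582000 nM; > 537000 nM (2 entries)

Whether the step is particular to chloro remains open, since fluoro, bromo, methyl or methoxy at this place are not among the compounds shown. Going by these compounds, how a primary amide in place of the carboxylic acid would read in this assay also remains open.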